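The compounds below may be only part of what the source reports. "The series", "measured", "known", "first", "only" and "open" are said of these compounds alone.

Compound 1 `CSc1nc(N)c2ncn([C@H]3C[C@H](OP(=O)(O)O)[C@]4(COP(=O)(O)O)C[C@H]34)c2n1`: 863 nM
Compound 2 `CNc1ncnc2c1ncn2[C@H]1C[C@H](OP(=O)(O)O)[C@]2(COP(=O)(O)O)C[C@H]12`: 17.6 nM

In an in vitro assay on Sf9 cells for binding affinity to P2Y purinoceptor 1 (Homo sapiens) (on this read-out higher numbers stand for weaker inhibition and lower numbers for stronger inhibition), compound 2 gives the lower of the two numbers shown, and compound 1 stands well above it, beyond the usual scatter. Compound 3 `CCCCCCc1nc(NC)c2ncn([C@H]3C[C@H](OP(=O)(O)O)[C@]4(COP(=O)(O)O)C[C@H]34)c2n1` differs from compound 2 by one change: hexyl in place of hydrogen on an aromatic carbon. Among the measured compounds shown here, no measured pair shows this change, so its effect has to be guessed. A modest weakening is expected, with the step of a 2.3-fold higher number from compound 2 to compound 3 (0.36 log units; beyond the scatter) likely small. Compound 3 is estimated at 40 nM, with a range from 10 nM to 200 nM.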

Compound 3, inhibition constant: 80 nM
Estimate against measurement, compound 3: 2.0-fold (0.30 log units) below; measured number inside the range.
By their numbers in this assay, from the lowest: compound 2; then compound 3; then compound 1.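

In this assay, hexyl in place of hydrogen on the aromatic carbon between two ring nitrogen atoms gives a 4.5-fold higher number from compound 2 to compound 3 (0.66 log units; beyond the scatter). This position therefore accepts a six-carbon chain with a modest loss of inhibition, not a complete one. Nothing shown here explains the loss. The compounds shown leave open whether a shorter chain such as ethyl or butyl would cost less than hexyl, and whether an amine or a carboxylic acid at the end of the chain would change the number in either direction.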